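Methoxy in place of trifluoromethyl on compound 2

The compounds below may be only part of what the source reports. "The series", "measured", "known", "first", "only" and "open" are said of these compounds alone.

For the measured compounds named here, compound 2 `Cc1cc(NC(=O)Nc2ccc(C(F)(F)F)cc2)c2ccccc2n1` gives 23000 nM in an ADME assay on Raji cells (Homo sapiens) for cytotoxicity, with a stated time of 72 h (on this read-out higher numbers stand for an effect only at larger amounts of compound and lower numbers for an effect already at smaller amounts), and holds the only actual number so far. Compound 1 `COc1ccc(NC(=O)Nc2cc(C)nc3ccccc23)cc1OC` stands at > 25000 nM as a limit and not a number. Compound 3 `COc1ccc(NC(=O)Nc2cc(C)nc3ccccc23)cc1` differs from compound 2 methoxy in place of trifluoromethyl on an aromatic carbon by carrying methoxy in place of trifluoromethyl on an aromatic carbon. Going by the values given here, no measured step is available to guide this change, so in this assay none beyond the scatter is expected, in neither direction. The estimated step of a 1.1-fold higher number from compound 2 to compound 3 (0.04 log units; within the scatter) stays within that scatter. Compound 3 is estimated at 25000 nM (expected range 12000 nM to 50000 nM).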

Compound 3, half-maximal effective concentration: > 25000 nM
Compound 3: a limit, no number; the forecaster's own chance of this, stated with the estimate: 60%; the middle value sits exactly at the limit.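

In this assay, for the compounds shown here, methoxy in place of trifluoromethyl on the aromatic carbon gives an at least 1.0-fold higher number from compound 2 to compound 3 (0.03 log units; that floor lies within the scatter), so the first step at this position is only a floor and shows no change beyond the scatter. Compound 1 and compound 3 both stand as limits, and the step between them cannot be read. The values shown gather at one limit: the limit of > 25000 nM in this assay, at which 2 of the 3 values shown sit.

The compounds shown leave open whether an amine or a carboxylic acid on this carbon would give a readable number. They also leave open how far compound 3 actually lies from compound 2.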